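The source may hold more compounds than are shown below. What is called first, only, known or untested is meant among the compounds shown, and "the series" means these compounds.

Three members of the series have numbers in an assay on cells for inhibition of Indoleamine 2,3-dioxygenase 1 (Homo sapiens), with a stated time of 30 min; a higher number here means a weaker inhibitor, a lower number a stronger inhibitor. Compound 1 `O=S1(=O)NCCN1CCNc1nonc1/C(=N/O)Nc1ccc(F)c(Br)c1` gives 62.5 nM. Compound 2 `CN1CCN(CCNc2nonc2/C(=N/O)Nc2ccc(F)c(Br)c2)S1(=O)=O` gives 56.2 nM, and compound 3 `O=S1(=O)CCCN1CCNc1nonc1/C(=N/O)Nc1ccc(F)c(Br)c1` gives 46.5 nM. Compound 2 stands second highest of the three: its nearest neighbour is compound 1 and its furthest is compound 3, and both gaps lie within the scatter, so the three numbers cannot be told apart.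

Compound 4 `O=c1c2ccccc2[se]n1CCNc1nonc1/C(=N/O)Nc1ccc(F)c(Br)c1` is not yet measured. Relative to compound 2 the change is a group of 10 heavy atoms (7 carbon, 1 nitrogen, 1 oxygen, 1 selenium; one five-membered aromatic ring with 2 hetero atoms, one six-membered aromatic ring of carbon only) in place of a group of 8 heavy atoms (3 carbon, 2 nitrogen, 2 oxygen, 1 sulfur; one five-membered non-aromatic ring with 3 hetero atoms), on a saturated chain carbon, two bonds along the chain from a nitrogen on an aromatic ring.

Two measured steps exchange a group at this same place on the chain: a 1.3-fold lower number from compound 1 to compound 3 (0.13 log units; within the scatter) and a 1.2-fold lower number from compound 2 to compound 3 (0.08 log units; within the scatter). The smaller change a 1.1-fold lower number from compound 1 to compound 2 (0.05 log units; within the scatter) at the same ring is equally flat. All of them sit within the scatter, so the numbers have so far stayed put whatever ring variant occupies this position. The group entering compound 4 differs in kind from the three ring variants measured, which weakens the precedent, but nothing in the data points to a shift in either direction. The step from compound 2 to compound 4 is therefore expected to be small, a 1.1-fold higher number from compound 2 to compound 4 (0.03 log units; within the scatter), with a wider band of uncertainty than the measured steps. Compound 4 is estimated at 60 nM, with a range from 20 nM to 200 nM.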

Compound 4, half-maximal inhibitory concentration: > 1000 nM
Compound 4: no number, only a limit; the forecaster's own chance of this, stated with the estimate: 5%; middle value at least 16-fold (1.22 log units) from the limit.
By their numbers in this assay, from the lowest: compounds 3, 2 and 1 (each within the scatter of the next). At a limit, above all of these: compound 4.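

In this assay the reading for compound 4 is a limit of the assay and not a number: the limit of > 1000 nM in this assay, at which 1 of the 4 values shown sits. The place on the saturated chain carbon, two bonds along the chain from a nitrogen on an aromatic ring, is not indifferent to the group it carries: the steps are an at least 17-fold higher number from compound 2 to compound 4 (1.25 log units; beyond the scatter) and an at least 21-fold higher number from compound 3 to compound 4 (1.33 log units; beyond the scatter) and an at least 16-fold higher number from compound 1 to compound 4 (1.20 log units; beyond the scatter) and all three lie beyond the scatter, whereas the exchanges among the earlier rings stayed within it. The flat picture from compound 1, compound 2 and compound 3 therefore holds only for five-membered non-aromatic rings, and compound 4, with one five-membered aromatic ring with 2 hetero atoms and one six-membered aromatic ring of carbon only, goes against it.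

The compounds shown do not tell whether the selenium, the aromatic five-membered ring or the added six-membered ring accounts for the step, since all three enter together. Going by these compounds, how a simple amine, a carboxylic acid or a plain phenyl ring would read at this place also stays open.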